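The compounds below may be only part of what the source reports. "The series", "measured", "known", "first", "only" and "open" are said of these compounds alone.

Measured compounds:
- compound 1 `COc1cc2nc(N3CCCN(C(=O)N4CCOCC4)CC3)nc(N)c2c(-c2ccccn2)c1OC`: in an ADME assay on microsomes from liver (Homo sapiens) for protein binding, tested at 1 uM (on this read-out lower numbers stand for a smaller free fraction and higher numbers for a larger free fraction), compound 1 gives 1
- compound 2 `COc1cc2nc(N3CCCN(C(=O)N4CCOCC4)CC3)cc(N)c2c(-c2ccccc2)c1OC`: in this assay compound 2 gives 0.414
- compound 3 `COc1cc2nc(N3CCc4ncccc4C3)nc(N)c2c(-c2ncccn2)c1OC`: in this assay compound 3 gives 0.823

Compound 2 holds the lowest of the three numbers; compound 3 stands within the scatter of it, while compound 1 lies beyond the scatter above it. Among the compounds with values here, no single-point step between measured compounds is available, so the series gives no measured anchor for the change to compound 4 `COc1cc2nc(N3CCCN(C(=O)N4CCOCC4)CC3)cc(N)c2c(-c2ccc(F)cc2)c1OC`. Compound 4 differs from compound 2 by fluoro in place of hydrogen on an aromatic carbon. Within the data shown here, with no measured precedent, the step from compound 2 to compound 4 is expected to be small, if anything a slight lowering, and is estimated at a 1.2-fold lower number from compound 2 to compound 4 (0.06 log units; within the scatter), not beyond the scatter. Compound 4 is therefore expected to give about 0.36, with a range from 0.2 to 0.65.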

Compound 4, unbound fraction: 0.331
Compound 4: middle estimate off by 1.1-fold (0.04 log units), on the high side; the measured number falls inside the stated range.
By their numbers in this assay, from the lowest: compounds 4, 2, 3 and 1 (each within the scatter of the next, the first and the last beyond it).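

In this assay, within the data shown here, fluoro in place of hydrogen on the phenyl ring, para to a large group, gives a 1.3-fold lower number from compound 2 to compound 4 (0.10 log units; within the scatter) and is the first single-point step, so at this position the change cannot be told from the scatter. No measurement shown bears on the reason for this result.

As far as these compounds go, whether trifluoromethyl, an amine or a carboxylic acid at this position would move the free fraction beyond the scatter remains open. So does whether fluoro on the other carbons of this ring would give a step of similar size.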